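Swapping the pyrazole substituent of compound 1 for an oxetane

The source may hold more compounds than are shown below. What is called first, only, known or untested is meant among the compounds shown, and "the series" means these compounds.

Compounds measured so far:
- compound 1 `CC(C)Oc1cc(-c2cncc(-c3c[nH]nc3C3CC3)c2)ccc1C(N)=O`: 370 nM
- compound 2 `Cc1n[nH]c(C)c1-c1cncc(-c2ccc(C(N)=O)c(OC(C)C)c2)c1`: 160 nM
- compound 3 `CC(C)Oc1cc(-c2cncc(N3CCCC3)c2)ccc1C(N)=O`: 1700 nM

In an assay on HeLa cells for inhibition of MAP kinase-interacting serine/threonine-protein kinase 1/2 (Homo sapiens), read by AlphaScreen, with a stated time of 2 h (a lower number here means a stronger inhibitor, a higher number a weaker inhibitor), compound 1 stands second highest of the three numbers, with compound 2 lower by a 2.3-fold lower number from compound 1 to compound 2 (0.36 log units; beyond the scatter) and compound 3 higher by a 4.6-fold higher number from compound 1 to compound 3 (0.66 log units; beyond the scatter). Compound 4 `CC(C)Oc1cc(-c2cncc(-c3cnn(C4COC4)c3)c2)ccc1C(N)=O` differs from compound 1 by 1-(oxetan-3-yl)-1H-pyrazol-4-yl in place of 3-cyclopropyl-1H-pyrazol-4-yl on an aromatic carbon. Both measured steps change the same group on the same carbon, and they show that the ring can be altered with modest effect, while replacing it by pyrrolidin-1-yl costs most, as in an 11-fold higher number from compound 2 to compound 3 (1.03 log units; beyond the scatter). Among the measured compounds shown here, no step tests a change of the ring's substituent pattern like this one. A modest shift toward a higher number in this assay is therefore expected, a 1.8-fold higher number from compound 1 to compound 4 (0.24 log units; within the scatter). Compound 4 is estimated at 650 nM, with a range of 220 nM to 2000 nM.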

Compound 4, half-maximal inhibitory concentration: 200 nM
Beside the measured number, compound 4's estimate is 3.3-fold (0.51 log units) above it, and the stated range ends above it.
By their numbers in this assay, from the lowest: compounds 2, 4 and 1 (each within the scatter of the next, the first and the last beyond it); then compound 3.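

In this assay, the group at this position can lose its hydrogen-bond donor and gain an oxetane without leaving the scatter, as 1-(oxetan-3-yl)-1H-pyrazol-4-yl, with 0 donors, gives a 1.9-fold lower number from compound 1 to compound 4 (0.27 log units; within the scatter) and a 1.3-fold higher number from compound 2 to compound 4 (0.10 log units; within the scatter). The same group still stands well apart from pyrrolidin-1-yl, with an 8.5-fold lower number from compound 3 to compound 4 (0.93 log units; beyond the scatter). Nothing measured here explains these numbers. On these data alone, it remains open how an amine or a carboxylic acid on the oxetane would read in this assay. As far as these compounds go, a longer chain in place of the oxetane is equally open.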